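Bromo in place of methyl: expectation for compound 3

The compounds below may be only part of what the source reports. "The series", "measured", "known", "first", "only" and "open" are said of these compounds alone.

Compound 1 `Brc1ccc(NCc2cn(-c3ccccc3)nc2-c2ccccc2)cc1`: 52000 nM
Compound 2 `Cc1ccc(NCc2cn(-c3ccccc3)nc2-c2ccc(C)cc2)cc1`: > 100000 nM

In an ADME assay on Vero 76 cells (Chlorocebus sabaeus) for cytotoxicity, read by MTT assay, with a stated time of 96 h (on this read-out higher numbers stand for lower toxicity in this test and lower numbers for higher toxicity in this test), compound 2 gives > 100000 nM, which is a limit and not a number. Compound 3 `Cc1ccc(-c2nn(-c3ccccc3)cc2CNc2ccc(Br)cc2)cc1` has bromo in place of methyl on an aromatic carbon, para to a large group, so (4-methylphenyl)amino becomes (4-bromophenyl)amino (bromo in place of methyl on an aromatic carbon). Compound 1 carries the same (4-bromophenyl)amino group and gives 52000 nM, so a move toward lower numbers in this assay is expected. The expected change is an at least 2.0-fold lower number from compound 2 to compound 3 (0.30 log units; that floor lies within the scatter). For compound 3 the estimated value is 50000 nM, with an expected range of 22000 nM to 100000 nM.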

Compound 3, half-maximal cytotoxic concentration: 92000 nM
Estimate against measurement, compound 3: 1.8-fold (0.26 log units) below; the range from low to high includes it.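

In this assay, bromo in place of methyl on an aromatic carbon gives an at least 1.0-fold lower number from compound 2 to compound 3 (0.03 log units; that floor lies within the scatter), and this step rests on a limit and not a number: the limit of > 100000 nM in this assay, at which 1 of the 3 values shown sits.

With the (4-bromophenyl)amino group held constant, methyl in place of hydrogen on an aromatic carbon gives a 1.8-fold higher number from compound 1 to compound 3 (0.25 log units; within the scatter), so compound 1 and compound 3 cannot be told apart here. Going by these compounds, the size of the bromo step stays open while compound 2 stands at a limit. On these data alone, how a carboxylic acid or an amine in place of bromo would read in this assay also stays open.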